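This account rests on a few compounds, and the source may have more. Where it says the series, first, only, none or still open, it means among the compounds named here.

The measured compounds:
compound 1 `CCOC(=O)/C=N/c1cnc(Nc2ccc(N3CCN(C)CC3)cc2)nc1NC1CCCC1`, in a functional assay on HeLa cells (Homo sapiens) for antiproliferative activity, read by MTT assay (on this read-out higher numbers stand for weaker inhibition and lower numbers for stronger inhibition), compound 1 gives 19000 nM
compound 2 `CCOC(=O)/C=N/c1cnc(Nc2ccc(S(N)(=O)=O)cc2)nc1NC1CCCC1`, in this assay compound 2 gives 20700 nM
compound 3 `NS(=O)(=O)c1ccc(Nc2ncc(/N=C/c3cccs3)c(NC3CCCC3)n2)cc1`, in this assay compound 3 gives 10900 nM

Compound 2 gives the highest of the three numbers, though its nearest neighbour is compound 1 a 1.1-fold higher number from compound 1 to compound 2 (0.04 log units; within the scatter) and its furthest is compound 3 a 1.9-fold lower number from compound 2 to compound 3 (0.28 log units; within the scatter); both steps lie within the scatter, so the three compounds cannot be ordered on these numbers.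

Compound 4 `CCOC(=O)/C=N/c1cnc(Nc2ccc(S(N)(=O)=O)cc2)nc1NC1CC1` has not yet been measured. It differs from compound 2 in one place: cyclopropyl in place of cyclopentyl on a nitrogen on an aromatic ring. Neither of the measured steps touches this part of the molecule: the step from compound 1 to compound 2 changes the group on the aromatic carbon, and the step from compound 2 to compound 3 changes the group on the carbon with a double bond to nitrogen. Among the measured compounds shown here, both steps were within the scatter, which shows only that two other changes to this core moved the numbers little. For the measured compounds named here, there is no direct precedent for exchanging the cyclopentylamino for a cyclopropylamino, so the expected step from compound 2 to compound 4 is set near zero with a wide range, a 1.2-fold higher number from compound 2 to compound 4 (0.06 log units; within the scatter). Compound 4 is therefore expected to give about 24000 nM, between 8000 nM and 75000 nM.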

Compound 4, half-maximal inhibitory concentration: > 100000 nM
Compound 4: only a limit was reported; the forecaster's own chance of this, stated with the estimate: 10%; middle value at least 4.1-fold (0.61 log units) away from the limit.
By their numbers in this assay, from the lowest: compounds 3, 1 and 2 (each within the scatter of the next). At a limit, above all of these: compound 4.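

Compound 4 gives > 100000 nM in this assay, which is a limit of the assay and not a number: the limit of > 100000 nM in this assay, at which 1 of the 4 values shown sits.

Even so, the change from cyclopentylamino to cyclopropylamino gives the only step shown that lies beyond the scatter: an at least 4.8-fold higher number from compound 2 to compound 4 (0.68 log units; beyond the scatter). Among the compounds shown here, the two earlier steps, at the aromatic carbon and at the carbon with a double bond to nitrogen, stayed within the scatter, so this result is the first sign that the numbers respond to a change in one place, the group on the nitrogen on an aromatic ring, with cyclopentyl here giving a number that cyclopropyl does not match.

The compounds shown hold only these two rings at this place, so they leave open how a cyclobutyl or cyclohexyl ring, an open chain such as isopropyl, or an unsubstituted amine would behave there. They also leave open whether cyclopropyl in place of cyclopentyl has the same outcome when the core carries the thiophen-2-yl group of compound 3 or the 4-methylpiperazin-1-yl group of compound 1.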